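The source may hold more compounds than are shown below. What is called first, only, known or untested is meant among the compounds shown, and "the series" means these compounds.

Measured compounds and their values:

Compound 1, `COc1cc(-c2cc(/C=C/C(=O)c3ccc(N)cc3)[nH]n2)cc(OC)c1OC`: in a functional assay on SK-OV-3 cells (Homo sapiens) for cytotoxicity, read by sulforhodamine B assay, with a stated time of 48 h, tested at 1 uM (a higher number here means a weaker effect of the compound at the concentration tested, a lower number a stronger effect), compound 1 gives 104%.
Compound 2, `COc1ccc(-c2cc(/C=C/C(=O)c3ccc(N)cc3)[nH]n2)cc1`: in this assay compound 2 gives 105%.
Compound 3, `COc1cc(C(=O)/C=C/c2cc(-c3cc(OC)c(OC)c(OC)c3)n[nH]2)cc(OC)c1OC`: in this assay compound 3 gives 96%.

All three numbers tell the same story: at the concentration used, none of these compounds does much to the cells, and the readings sit close to what untreated cells would show. Compound 1 lies within the usual scatter of both compound 2 and compound 3, so the three values cannot be told apart in any meaningful way.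

Compound 4, `COc1cc(-c2cc(/C=C/C(=O)c3ccc(F)c(F)c3)[nH]n2)cc(OC)c1OC`, has not yet been tested. It keeps the core of compound 1 and changes only one part: 3,4-difluorophenyl in place of 4-aminophenyl on a carbonyl carbon. The ring that carries the carbonyl thus loses its nitrogen and gains two fluorine atoms.

Among the compounds with values here, no pair of measured compounds shows a single change of this kind, so there is no measured step to lean on. Since every measured compound shows only a weak effect, the expected step of a number 4 percentage points lower from compound 1 to compound 4 (within the scatter) is no change beyond the scatter. Compound 4 is therefore expected to give about 100%, with a likely range from 85% to 112%.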

Compound 4, a percentage reported as activity, at one concentration (the size of the read-out at that concentration, not a potency): 90%
For compound 4 the middle estimate is 10 percentage points above the measured one; low and high end bracket the measured number.
By their numbers in this assay, from the lowest: compounds 4, 3, 1 and 2 (each within the scatter of the next, the first and the last beyond it).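

In this assay, putting 3,4-difluorophenyl in place of 4-aminophenyl on a carbonyl carbon gives a number 14 percentage points lower from compound 1 to compound 4 (beyond the scatter) and so provides the first difference in this set that stands clear of the scatter, showing that the reading can respond to a change at this place, although compound 4 at 90% still shows only a modest effect at the concentration tested. Within the data shown here, the single swap removes the 4-aminophenyl group, with 1 hydrogen-bond donor and 1 hydrogen-bond acceptor, and brings in 3,4-difluorophenyl, with 0 of each, so losing the nitrogen and gaining the two fluorine atoms happen together and their contributions cannot be separated. Nothing available here accounts for the shift.

Still open, as far as these compounds go, is whether the drop depends on removing the amine or on adding fluorine, a question that a plain phenyl or a 4-fluorophenyl group on the same carbonyl carbon would help to settle. Also unresolved is whether a 4-chlorophenyl or 4-methoxyphenyl group there would move the reading further or leave it within the scatter of compound 4.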